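This account rests on a few compounds, and the source may have more. Where it says the series, first, only, none or still open, it means among the compounds named here.

In a functional assay on SMMC-7721 cells (Homo sapiens) for antiproliferative activity, read by MTT assay, with a stated time of 72 h (on this read-out higher numbers stand for weaker inhibition and lower numbers for stronger inhibition), compound 1 `C/C(=N\NC(=O)c1cccc(S(=O)(=O)N2CCOCC2)c1)c1ccc(F)cc1` gives > 100000 nM, which is a limit of the assay. Compound 2 `C/C(=N\NC(=O)c1cccc(S(=O)(=O)N2CCOCC2)c1)c1cc(O)ccc1O` gives > 100000 nM, also a limit and not a number. Both compounds therefore sit at the limit of > 100000 nM in this assay, at which 2 of the 2 values shown sit. Compound 3 `C/C(=N\NC(=O)c1cccc(S(=O)(=O)N2CCOCC2)c1)c1cc(F)ccc1O` differs from compound 2 by fluoro in place of hydroxy on an aromatic carbon, with fluoro in place of hydroxy on an aromatic carbon. Among the compounds with values here, the only measured step that bears on this change is a step that the two limits leave unreadable from compound 1 to compound 2, so no step beyond the scatter is expected. The estimated change is a number no higher from compound 2 to compound 3 (the limit leaves the size open). Compound 3 is expected at 100000 nM, with an estimated range of 30000 nM to 200000 nM.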

Compound 3, half-maximal inhibitory concentration: 1150 nM
Compound 3: the middle estimate sits 87-fold (1.94 log units) above what was measured, outside the stated range (below it).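

In this assay, this place on the ring proves able to carry a large change: fluoro in place of hydroxy, para to a hydroxy group, gives an at least 86-fold lower number from compound 2 to compound 3 (1.93 log units; beyond the scatter). The 5-fluoro-2-hydroxyphenyl group in place of 4-fluorophenyl likewise gives an at least 86-fold lower number from compound 1 to compound 3 (1.93 log units; beyond the scatter), so among these compounds a fluoro group and a hydroxy group together on the ring go with a readable value. Compound 3 alone stands off the limit, and the other two compounds remain limits and not numbers: the limit of > 100000 nM in this assay, at which 2 of the 3 values shown sit.

The compounds shown leave open whether chloro, methoxy or an amine at this place would give a similar step. They also leave open whether the step depends on the hydroxy group that stays on the ring.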